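The source may hold more compounds than are shown below. What is called first, only, known or untested is meant among the compounds shown, and "the series" means these compounds.

In a functional assay on DU-145 cells (Homo sapiens) for inhibition (on this read-out lower numbers stand for stronger inhibition of growth and higher numbers for weaker inhibition of growth), the measured compounds read as follows:
compound 1 `COc1ccc(-n2cnnc2-c2cc(OC)c(OC)c(OC)c2)cc1` gives 2950 nM
compound 2 `COc1cc(-c2nncn2-c2ccc(N(C)C)cc2)cc(OC)c1OC` gives 1860 nM
compound 3 `COc1ccc(-n2cnnc2-c2cc(OC)c(OC)c(OC)c2)cc1O` gives 661 nM

Compound 3 holds the lowest of these three numbers, and both other compounds lie beyond the scatter from it. The next comparison turns to compound 4 `COc1ccc(-n2cnnc2-c2cc(OC)c(OC)c(OC)c2)cc1F` and exchanges the hydroxy group of compound 3 for fluoro on an aromatic carbon, ortho to a methoxy group and meta to a large group. Going by the values given here, the counted difference is fluoro in place of hydroxy on an aromatic carbon and it stands as the only structural change.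

The closest evidence is the step that introduced hydroxy in place of hydrogen at this same carbon, a 4.5-fold lower number from compound 1 to compound 3 (0.65 log units; beyond the scatter) and modest in size. The exchange of dimethylamino for methoxy, a 1.6-fold lower number from compound 1 to compound 2 (0.20 log units; within the scatter) is a different change and offers little guidance. Among the compounds with values here, no fluoro compound has been measured, so the size of this step remains uncertain. If fluoro does not reproduce what hydroxy showed in compound 3, a modest rise is expected, probably smaller than the full hydroxy step. In this assay the expected change is a 2.3-fold higher number from compound 3 to compound 4 (0.36 log units; beyond the scatter) as an estimate. For compound 4 the estimated value is 1500 nM with an expected range from 450 nM to 5000 nM in this series.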

Compound 4, concentration for 50% growth inhibition: 4790 nM
Beside the measured number, compound 4's estimate is 3.2-fold (0.50 log units) below it; measured number inside the range.
By their numbers in this assay, from the lowest: compound 3; then compounds 2, 1 and 4 (each within the scatter of the next, the first and the last beyond it).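

Set against compound 3 in this assay, fluoro in place of hydroxy gives a clear step (a 7.2-fold higher number from compound 3 to compound 4 (0.86 log units; beyond the scatter)), so the lower number that came with hydroxy on this carbon does not carry over to fluoro. Set against compound 1, which has hydrogen on the same carbon, the fluoro compound stays within the scatter (a 1.6-fold higher number from compound 1 to compound 4 (0.21 log units; within the scatter)), so this read-out does not separate fluoro from hydrogen here, and of the two groups placed on this carbon only hydroxy moves the number beyond the scatter. The exchange takes away the hydrogen-bond donor and acceptor counted for hydroxy, but no measurement at hand bears on why the two groups part so far.

The compounds shown leave open whether the result belongs to hydroxy alone or would extend to other groups on this carbon, such as an amine or a hydroxymethyl group. They also leave open whether hydroxy on this carbon would lower the number in the same way with dimethylamino in place of the methoxy group, as in compound 2.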